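Chloro to fluoro exchange on the aryl ring, two positions

This account rests on a few compounds, and the source may have more. Where it says the series, first, only, none or still open, it means among the compounds named here.

Compound 2 `Clc1ccccc1CSc1nnc(-c2ccncc2)n1-c1ccccc1` and compound 1 `Fc1ccccc1CSc1nnc(-c2ccncc2)n1-c1ccccc1` share one core and differ by fluoro in place of chloro on an aromatic carbon. In a functional assay on MCF7 cells (Homo sapiens) for inhibition, read by MTT assay, with a stated time of 48 h (on this read-out higher numbers stand for weaker inhibition and lower numbers for stronger inhibition), compound 2 gives 18100 nM. For compound 1 the result in this assay is a limit of the assay, > 50000 nM. Because of the limit of > 50000 nM in this assay, at which 1 of the 3 values shown sits, the step of an at least 2.7-fold higher number from compound 2 to compound 1 (0.44 log units; beyond the scatter) is known only as a bound. Compound 3 `O=C(CSc1nnc(-c2ccncc2)n1-c1ccccc1)N/N=C/c1ccc(Cl)cc1` gives 9930 nM in this assay; the difference between the cores of compound 2 and compound 3 is not broken down here. Compound 4 `O=C(CSc1nnc(-c2ccncc2)n1-c1ccccc1)N/N=C/c1ccc(F)cc1` carries the same kind of change, (fluoro in place of chloro on an aromatic carbon), but the surroundings differ: in compound 1 the group sits ortho to a large group, in compound 4 para to a large group. Within the data shown here, the step of an at least 2.7-fold higher number from compound 2 to compound 1 (0.44 log units; beyond the scatter) is the only measured instance of this change and is the basis of the expectation. On this basis a step of a 2.5-fold higher number from compound 3 to compound 4 (0.40 log units; beyond the scatter) is expected. Compound 4 is thus estimated at 25000 nM, with a range from 10000 nM to 70000 nM.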

Compound 4, half-maximal inhibitory concentration: 12300 nM
Compound 4: the middle estimate sits 2.0-fold (0.31 log units) above what was measured, within the range that was stated.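

In this assay the exchange of 4-chlorophenyl to 4-fluorophenyl gives a 1.2-fold higher number from compound 3 to compound 4 (0.09 log units; within the scatter) and so shows no readable change on the core of compound 3. The two pairs differ both in the core and in where the halogen sits on the ring, and the data do not separate these two differences. The exchange therefore cannot be given a single size across the two cores, and whether it carries over stays undecided: the same change on two cores in this assay, an at least 2.7-fold higher number (0.44 log units; beyond the scatter) from compound 2 to compound 1 and a 1.2-fold higher number (0.09 log units; within the scatter) from compound 3 to compound 4; the limit leaves it open whether they differ

Compound 3 gives 9930 nM in this assay, and open is whether a methoxy, a trifluoromethyl, a nitrile or an amine in place of the halogen on the 4-substituted phenyl would move that value by more than the scatter. Also open, on these data alone, is how the exchange behaves on the core of compound 1 when the starting value and the end value are both numbers rather than a limit.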